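This account rests on a few compounds, and the source may have more. Where it says the series, first, only, none or still open, it means among the compounds named here.

In an ADME assay on microsomes from liver (Mus musculus) for metabolic stability, read by LC-MS, with a stated time of 60 min, tested at 10 uM (on this read-out lower numbers stand for a shorter-lived compound and higher numbers for a longer-lived compound), compound 1, `CC(C)c1noc(C2CCN(C(=O)[C@@H]3CCCN(S(=O)(=O)c4ccc(S(=O)(=O)C(C)C)cc4)C3)CC2)n1`, gives 0.543 h. Compound 2, `CC(C)c1noc(N2CCN(C(=O)[C@@H]3CCCN(S(=O)(=O)c4ccc(S(=O)(=O)C(C)C)cc4)C3)CC2)n1`, is a different case: in this assay compound 2 gives > 1 h, which is a limit of the assay rather than a number. Compound 2 therefore sits at the limit of > 1 h in this assay, at which 1 of the 2 values shown sits, so only a floor is known for it.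

Compound 3, `CCN(CC)S(=O)(=O)c1ccc(S(=O)(=O)N2CCC[C@@H](C(=O)N3CCN(c4nc(C(C)C)no4)CC3)C2)cc1`, differs from compound 2 in one place: diethylamino in place of isopropyl on a sulfonyl sulfur. Among the measured compounds shown here, no pair of measured compounds shows this change, so there is no measured step to lean on; the expectation rests on compound 2 standing at the limit and on the change being a modest swap of one small group for another. The step is expected to be small, a step that the limit leaves unreadable from compound 2 to compound 3, not beyond the usual scatter. Compound 3 is therefore expected to give 1.2 h in this assay, with a likely range from 0.5 h to 2.5 h.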

Compound 3, half-life: 0.128 h
Compound 3: the middle estimate sits 9.4-fold (0.97 log units) above what was measured; measured number below the stated range.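

In this assay, replacing isopropyl with diethylamino on a sulfonyl sulfur, which turns isopropylsulfonyl into diethylsulfamoyl, gives an at least 7.8-fold lower number from compound 2 to compound 3 (0.89 log units; beyond the scatter), so a swap of one small group at this place can clearly shorten the half-life. Compound 1 and compound 2 both carry isopropylsulfonyl, so they said nothing about this place. The step has only a lower bound on its size, because the value for compound 2 is a limit of the assay and not a number: the limit of > 1 h in this assay, at which 1 of the 3 values shown sits.

A single pair cannot separate the effect of the entering nitrogen from that of the extra carbons, and a dimethylamino group or a plain methyl on the same sulfur would speak to that. From the compounds shown here alone, whether the swap acts alike on compound 1 also stays open.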